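Adding a Chloro Group to a Weak Kinase Inhibitor

This account rests on a few compounds, and the source may have more. Where it says the series, first, only, none or still open, it means among the compounds named here.

Compound 1, `Nc1nc(-c2ccccc2)nn1-c1ncnc2cc(Cl)ccc12`, gives > 40000 nM in an assay on MCF7 cells for inhibition of Serine-protein kinase ATM (Homo sapiens), read by immunofluorescence, with a stated time of 1 h (a lower number here means a stronger inhibitor, a higher number a weaker inhibitor), which is a limit of the assay rather than a number.
Compound 2, `CCN(CC)c1nc(-n2nc(-c3ccccn3)nc2N)c2cc(OC)c(OC)cc2n1`, gives > 40000 nM in this assay, again a limit of the assay.
Compound 3, `COc1cc2ncnc(-n3nc(-c4ccccc4)cc3N)c2cc1OC`, gives 20600 nM in this assay.

Among the three compounds measured, compound 3 is the only one for which an actual number was obtained; the other two sit at the limit of > 40000 nM in this assay, at which 2 of the 3 values shown sit. Even so, the value of compound 3 marks it as a weak inhibitor, far from the potency that would make it a useful tool.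

Compound 4, `COc1cc2ncnc(-n3nc(-c4ccc(Cl)cc4)cc3N)c2cc1OC`, differs from compound 3 in exactly one place: chloro in place of hydrogen on an aromatic carbon. Within the data shown here, no measured pair in this set makes the same change, so there is no direct guide to what it does to the read-out. In the absence of such a guide, the expectation for this assay is a step no larger than the usual scatter of repeated measurements, in either direction, with a real chance that compound 4 drifts to the limit of the assay instead of giving a number.

Compound 4 is therefore expected to give 15000 nM, with a likely range from 5000 nM to 40000 nM. The step this estimate implies is a 1.4-fold lower number from compound 3 to compound 4 (0.14 log units; within the scatter).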

Compound 4, half-maximal inhibitory concentration: > 40000 nM
Compound 4: no number, only a limit (the forecaster's own chance of this, stated with the estimate: 25%); at least 2.6-fold (0.42 log units) between middle value and limit.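

Going from phenyl to 4-chlorophenyl is the first single change in this set that can be read, and in this assay it gives an at least 1.9-fold higher number from compound 3 to compound 4 (0.28 log units; that floor lies within the scatter). On these data alone, compound 4 has only a limit of the assay and no number, so chloro at this position, para to a large group, gives no sign of a stronger inhibitor, while the true size of the step stays unknown and the floor alone cannot separate a real loss from ordinary scatter. Compound 4 thereby joins the compounds that have no number: the limit of > 40000 nM in this assay, at which 3 of the 4 values shown sit.

Still open, as far as these compounds go, is whether a different group at this position, such as a methoxy, an amine or a carboxylic acid, would move the value of compound 3 in either direction. Also open, from the compounds shown here alone, is whether chloro on another carbon of the same ring would leave compound 3 with a measurable value, and whether any such change could bring this weak inhibitor closer to useful potency.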